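The compounds below may be only part of what the source reports. "The series", "measured", "known", "first", "only" and "open" are said of these compounds alone.

In a physicochemical assay for solubility, at pH 7 (a higher number here means a more soluble compound, a lower number a less soluble compound), compound 2 (`CN1CCC(C(=O)N2Cc3c(NC(=O)C4CC4)n[nH]c3C2(C)C)CC1`) gives > 225000 nM, which is a limit and not a number. Compound 1 (`CC(=O)N1CCN(C(=O)N2Cc3c(NC(=O)c4ccc(F)cc4)n[nH]c3C2(C)C)CC1`) also returns a limit, > 225000 nM. Compound 3 (`CC1(C)c2[nH]nc(NC(=O)c3ccc(F)cc3)c2CN1C(=O)C1CCN(C2CC2)CC1`) returns a limit too, > 225000 nM. All the data therefore stand at the limit of > 225000 nM in this assay, at which 3 of the 3 values shown sit, and compound 2 cannot be ranked against the others.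

The next compound, compound 4 (`CN1CCC(C(=O)N2Cc3c(NC(=O)c4cc(F)cc(F)c4)n[nH]c3C2(C)C)CC1`), has 3,5-difluorophenyl in place of cyclopropyl on a carbonyl carbon. Among the compounds with values here, no measured step makes this exchange. Within the data shown here, the only step available is a step that the two limits leave unreadable from compound 1 to compound 3, and it concerns a different change, 1-cyclopropylpiperidin-4-yl in place of 4-acetylpiperazin-1-yl on a carbonyl carbon, so it offers no size to carry over.

The closest guide is compound 3, which already holds a six-membered aromatic ring of carbon only on the corresponding carbonyl carbon and still gives the limit > 225000 nM. On that basis, no step beyond the scatter is expected, and the assay will most likely report a limit again, with any readable number expected to fall on the lower side. The estimated step is a number no higher from compound 2 to compound 4 (the limit leaves the size open). The expected value for compound 4 is 225000 nM, with an estimated range of 120000 nM to 250000 nM.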

Compound 4, solubility: > 225000 nM
Compound 4 ended at the assay's limit; the forecaster's own chance of this, stated with the estimate: 75%; the middle value sits exactly at the limit.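

In this assay compound 4 returns a limit, as compound 2 does, so the exchange of cyclopropyl for 3,5-difluorophenyl gives no readable step between compound 2 and compound 4. The compounds shown leave open how any of them ranks against another, since every value stands at the same limit: the limit of > 225000 nM in this assay, at which 4 of the 4 values shown sit.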